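A few compounds are considered here, and "the series" means these few. Any claim that something is new, unique, unknown or untested is made for them only; others in the source may bear on it.

Compound 1 `Cc1ccc2oc(-c3ccc(NC(=O)CN4CCN(CCN(C)C)CC4)cc3)nc2c1` is the reference point of this small set. In a functional assay on HT-29 cells (Homo sapiens) for cytotoxicity, read by MTT assay, with a stated time of 24 h (on this read-out higher numbers stand for weaker inhibition and lower numbers for stronger inhibition), compound 1 gives 1790 nM. Compound 2 `CN(C)CCN1CCN(CC(=O)Nc2ccc(-c3nc4cc(F)ccc4o3)cc2)CC1` carries one alteration relative to compound 1, namely (fluoro in place of methyl on an aromatic carbon), and in this assay compound 2 gives 8190 nM; the resulting step is a 4.6-fold higher number from compound 1 to compound 2 (0.66 log units; beyond the scatter). Compound 3 `Cc1ccc2oc(-c3ccc(NC(=O)CCl)cc3)nc2c1` belongs to a different series, and the difference between its core and that of compound 1 is not broken down here. In this assay compound 3 gives 15200 nM, the highest number of the three; its value and that of compound 2 lie within the usual scatter of each other, whereas its gap to compound 1 is beyond it.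

Compound 4 `O=C(CCl)Nc1ccc(-c2nc3cc(F)ccc3o2)cc1` has not yet been measured. It stands to compound 3 as compound 2 stands to compound 1, the change being (fluoro in place of methyl on an aromatic carbon), made at the same place in both pairs. Given that the earlier step was a 4.6-fold higher number from compound 1 to compound 2 (0.66 log units; beyond the scatter), compound 4 is expected to sit at 45000 nM, with an estimated step of a 3.0-fold higher number from compound 3 to compound 4 (0.47 log units; beyond the scatter), although the weak starting point of compound 3 means that only a limit might be reported.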

Compound 4, half-maximal inhibitory concentration: 6930 nM
Estimate against measurement, compound 4: 6.5-fold (0.81 log units) above; the measured number lies below the stated range.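

Read in this assay, the new pair gives a 2.2-fold lower number from compound 3 to compound 4 (0.34 log units; beyond the scatter), so fluoro in place of methyl on an aromatic carbon moves the number the opposite way from its course on the core of compound 1. The two steps therefore disagree in direction, and the change does not carry over from one core to the other as a fixed increment: the same change on two cores in this assay, a 4.6-fold higher number (0.66 log units; beyond the scatter) from compound 1 to compound 2 and a 2.2-fold lower number (0.34 log units; beyond the scatter) from compound 3 to compound 4, 10-fold (1.00 log units) apart, beyond the scatter of two such steps This shows that, in these two pairs, the outcome of the swap depends on the rest of the molecule, but it does not show which part of the rest is responsible or why, and two pairs set no rule for other cores in the series.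

The compounds shown leave open how other groups on that aromatic carbon, such as methoxy or a nitrile, would behave on either core. They also leave open which way the swap would go on a core whose amide chain ends in a morpholine or a carboxylic acid.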